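Bromoacetamide chalcone-triazoles: octyl to 4-bromobenzyl swap

The source may report more compounds than this note shows. Statements on the series, on what has been measured and on what is new or still open speak of the compounds shown alone.

Within the data shown here, compound 3 `CCCCCCCCn1cc(/C=C/C(=O)c2ccc(NC(=O)CBr)cc2)nn1` gives the lowest number of the three measured so far, 8420 nM in a functional assay on HeLa cells (Homo sapiens) for inhibition, read by MTT assay; a higher number here means a weaker inhibitor, a lower number a stronger inhibitor. Among the measured compounds shown here, compound 1 `CCCCCCCCn1cc(/C=C/C(=O)c2ccc(N)cc2)nn1` gives 26900 nM, and the step of a 3.2-fold lower number from compound 1 to compound 3 (0.50 log units; beyond the scatter) is the only matched pair in hand. For the measured compounds named here, compound 2 `O=C(CN1CCN(c2ccccc2)CC1)Nc1ccc(C(=O)/C=C/c2cn(Cc3ccc(Br)cc3)nn2)cc1` gives 79700 nM, the highest number of the set; it shares the 4-bromobenzyl group with the unmeasured compound but carries a different acyl group on the nitrogen on the aromatic ring, so its two values with compound 3 form no clean step.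

Compound 4 `O=C(CBr)Nc1ccc(C(=O)/C=C/c2cn(Cc3ccc(Br)cc3)nn2)cc1` differs from compound 3 by 4-bromophenyl in place of heptyl on a saturated chain carbon bound to an aromatic nitrogen. Going by the values given here, no measured step covers this change directly; the bromoacetamide step bears only on the group that stays constant. Among the compounds with values here, the one compound with the 4-bromobenzyl group, compound 2, sits at the weak end, which tilts the expectation toward a higher number, but with wide uncertainty. The expected step of a 1.8-fold higher number from compound 3 to compound 4 (0.25 log units; within the scatter) is estimated as a modest loss, with compound 4 expected at 15000 nM, within 5000 nM to 50000 nM.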

Compound 4, half-maximal inhibitory concentration: 7950 nM
Estimate against measurement, compound 4: 1.9-fold (0.28 log units) above, within the range that was stated.
By their numbers in this assay, from the lowest: compounds 4 and 3 (each within the scatter of the next); then compound 1; then compound 2.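

In this assay, the position on the saturated chain carbon bound to an aromatic nitrogen accepts 4-bromophenyl in place of heptyl with no change beyond the scatter, a 1.1-fold lower number from compound 3 to compound 4 (0.02 log units; within the scatter). At the saturated chain carbon bound to a carbonyl carbon, with the 4-bromobenzyl group held constant, a 10-fold lower number from compound 2 to compound 4 (1.00 log units; beyond the scatter) shows that the high number of compound 2 goes with the 4-phenylpiperazin-1-yl group, not with the 4-bromobenzyl group. No supporting evidence bears on why either step comes out as it does.

Going by these compounds, the octyl to 4-bromobenzyl swap is read only with the bromoacetamide in place, so its size on the free amine of compound 1 stays open. Also open, on these data alone, is whether a chloro or a dimethylamino group in place of bromo, or an unsubstituted benzyl or a longer chain on the aromatic nitrogen, would keep these numbers.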